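The source may hold more compounds than are shown below. What is called first, only, known or untested is meant among the compounds shown, and "the series" means these compounds.

Two compounds of the series carry numbers in an ADME assay on Li23 cells (Homo sapiens) for cytotoxicity, read by WST assay; a higher number here means that more compound is tolerated, a lower number that less compound is tolerated. Compound 1 `CCCCC(=O)N(C)c1ccc(C(O)(C(F)(F)F)C(F)(F)F)cc1` gives 26000 nM. Compound 2 `CN(c1ccc(C(O)(C(F)(F)F)C(F)(F)F)cc1)S(=O)(=O)c1ccccc1Cl` gives 15000 nM; this number and that of compound 1 lie within the scatter of each other, so no order between them can be read. Compound 3 `Cc1ccccc1S(=O)(=O)N(C)c1ccc(C(O)(C(F)(F)F)C(F)(F)F)cc1` is not yet measured. It differs from compound 2 by methyl in place of chloro on an aromatic carbon, the chloro leaving and the methyl entering on an aromatic carbon of a six-membered aromatic ring of carbon only. Among the measured compounds shown here, no measured pair shows this change, so nothing about its size is known from the series. In this assay the expected step is no change at the digits printed from compound 2 to compound 3 (within the scatter), none beyond the scatter, in no fixed direction. For compound 3 the estimate is 15000 nM, with a range from 7000 nM to 35000 nM.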

Compound 3, half-maximal cytotoxic concentration: 12000 nM
Estimate against measurement, compound 3: 1.3-fold (0.10 log units) above; the range from low to high includes it.
By their numbers in this assay, from the lowest: compounds 3, 2 and 1 (each within the scatter of the next, the first and the last beyond it).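

In this assay methyl in place of chloro on an aromatic carbon, ortho to a large group, gives a 1.3-fold lower number from compound 2 to compound 3 (0.10 log units; within the scatter) as the first measured size for this change in the series. The numbers therefore do not separate 2-chlorophenyl from 2-methylphenyl at this position. Nothing at hand bears on the reason for this result.

This single pair leaves open whether an amine or a carboxylic acid at this position would give a step beyond the scatter. It also leaves open how a longer chain there would read.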